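Exchanging the Aryl Group on the Amide Carbonyl

The compounds below may be only part of what the source reports. "The series", "measured", "known", "first", "only" and "open" are said of these compounds alone.

Three measured compounds share one core and differ only in the aryl group attached to the carbonyl carbon. In an assay on HEK293 cells for inhibition of Voltage-dependent N-type calcium channel subunit alpha-1B (Homo sapiens), read by FLIPR and calcium flux (a higher number here means a weaker inhibitor, a lower number a stronger inhibitor), compound 1 `CS(=O)(=O)c1ccc(C#N)cc1C(=O)N1CCC(N(C2CC2)S(=O)(=O)c2cccc(C(F)(F)F)c2)CC1` gives 670 nM, compound 2 `CS(=O)(=O)c1cc(C#N)ccc1C(=O)N1CCC(N(C2CC2)S(=O)(=O)c2cccc(C(F)(F)F)c2)CC1` gives 450 nM, and compound 3 `CS(=O)(=O)c1ccc(Cl)c(C(=O)N2CCC(N(C3CC3)S(=O)(=O)c3cccc(C(F)(F)F)c3)CC2)c1` gives 340 nM. Compound 3 holds the lowest of the three numbers, yet the steps of a 2.0-fold lower number from compound 1 to compound 3 (0.29 log units; within the scatter) and a 1.3-fold lower number from compound 2 to compound 3 (0.12 log units; within the scatter) both lie within the scatter, as does a 1.5-fold lower number from compound 1 to compound 2 (0.17 log units; within the scatter). Compound 4 `CS(=O)(=O)c1ccc(C(=O)N2CCC(N(C3CC3)S(=O)(=O)c3cccc(C(F)(F)F)c3)CC2)c(F)c1` differs from compound 3 in the same way: 2-fluoro-4-(methylsulfonyl)phenyl in place of 2-chloro-5-(methylsulfonyl)phenyl on a carbonyl carbon. Each measured step exchanged one such group on the carbonyl carbon without a change beyond the scatter, so the expected step of a 1.2-fold higher number from compound 3 to compound 4 (0.09 log units; within the scatter) is likewise small. Compound 4 is therefore estimated at 420 nM in this assay, with a range from 150 nM to 1200 nM.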

Compound 4, half-maximal inhibitory concentration: 350 nM
Compound 4: the middle estimate sits 1.2-fold (0.08 log units) above what was measured; measured number inside the range.
By their numbers in this assay, from the lowest: compounds 3, 4, 2 and 1 (each within the scatter of the next).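

In this assay, the new aryl group gives a 1.0-fold higher number from compound 3 to compound 4 (0.01 log units; within the scatter), a 1.3-fold lower number from compound 2 to compound 4 (0.11 log units; within the scatter) and a 1.9-fold lower number from compound 1 to compound 4 (0.28 log units; within the scatter). For the compounds shown here, it is the first group here to carry fluorine and the first with its methylsulfonyl numbered 4, and neither difference moves the number beyond the scatter, so all four aryl groups on the carbonyl carbon remain indistinguishable. Nothing available explains why these numbers stay so close. From the compounds shown here alone, what a carboxylic acid or an amine on this phenyl ring would do stays open, as does whether any group at this place can move the number beyond the scatter.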